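A ring-atom swap at the end of the chain

This account rests on a few compounds, and the source may have more. Where it says the series, first, only, none or still open, it means among the compounds named here.

Of the compounds shown here, two sharing one core have been tested in an ADME assay on HEK293-A cells (Homo sapiens) for cytotoxicity, read by MTT assay, with a stated time of 48 h; on this read-out lower numbers stand for stronger inhibition and higher numbers for weaker inhibition. Compound 1, `O=C1O[C@@H](CN2CCC(O)CC2)CN1c1ccc(-n2cc(-c3ccccn3)cn2)c(F)c1`, carries a 4-hydroxypiperidin-1-yl group; in this assay compound 1 gives > 400 ug/mL, which is a limit of the assay rather than a number. Compound 2, `O=C1CNC(=O)N1C[C@H]1CN(c2ccc(-n3cc(-c4ccccn4)cn3)c(F)c2)C(=O)O1`, carries 2,5-dioxoimidazolidin-1-yl in place of that group on a saturated chain carbon bound to a saturated ring carbon; in this assay compound 2 gives > 400 ug/mL, again a limit and not a number. The step that the two limits leave unreadable from compound 1 to compound 2 can therefore not be sized. Compound 2 thus stands only at a limit, and the same holds for every value shown: the limit of > 400 ug/mL in this assay, at which 2 of the 2 values shown sit.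

Compound 3, `O=C1CSC(=O)N1C[C@H]1CN(c2ccc(-n3cc(-c4ccccn4)cn3)c(F)c2)C(=O)O1`, differs from compound 2 by 2,4-dioxo-1,3-thiazolidin-3-yl in place of 2,5-dioxoimidazolidin-1-yl on a saturated chain carbon bound to a saturated ring carbon. For the measured compounds named here, no measured step bears directly on this change, and the single measured step is unreadable. Given that (the limit of > 400 ug/mL in this assay, at which 2 of the 2 values shown sit), compound 3 is expected to sit at the same limit, which means an expected step of a number no higher from compound 2 to compound 3 (the limit leaves the size open) in this assay. Compound 3 is accordingly estimated at 400 ug/mL, with a range from 200 ug/mL to 800 ug/mL.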

Compound 3, half-maximal inhibitory concentration: 283 ug/mL
Estimate against measurement, compound 3: 1.4-fold (0.15 log units) above; the range from low to high includes it.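

Compound 3 gives the first actual number at this position in this assay, so a group on this saturated chain carbon can bring the reading inside the measurable range, where the earlier compounds gave only a limit: the limit of > 400 ug/mL in this assay, at which 2 of the 3 values shown sit.

The swap of one five-membered ring for the other, 2,4-dioxo-1,3-thiazolidin-3-yl in place of 2,5-dioxoimidazolidin-1-yl, is an at least 1.4-fold lower number from compound 2 to compound 3 (0.15 log units; that floor lies within the scatter), and replacing the six-membered 4-hydroxypiperidin-1-yl group with that same ring is an at least 1.4-fold lower number from compound 1 to compound 3 (0.15 log units; that floor lies within the scatter). Both sizes are only floors, resting on a limit at one end, and as they stand they do not establish a real difference, though the true gaps could prove larger.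

This one change brings in the ring sulfur and removes the hydrogen-bond donor together, and the compounds shown do not tell these two apart. Going by these compounds, how other groups on this chain carbon would read also stays open, for example a morpholine ring, an open-chain amide or a carboxylic acid.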